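Thiophene for hydroxynaphthyl on the shared core

The source may report more compounds than this note shows. Statements on the series, on what has been measured and on what is new or still open speak of the compounds shown alone.

Measured so far:
compound 1 `COc1cc(N2C(N)=C(C#N)C(c3ccccc3O)C3=C2CC(C)(C)CC3=O)cc(OC)c1OC`: "not active" (no number reported)
compound 2 `COc1cc(N2C(N)=C(C#N)C(c3ccc(OC)c4ccccc34)C3=C2CC(C)(C)CC3=O)cc(OC)c1OC`: "not active" (no number reported)
compound 3 `COc1cc(N2C(N)=C(C#N)C(c3c(O)ccc4ccccc34)C3=C2CC(C)(C)CC3=O)cc(OC)c1OC`: 143000 nM

Among the measured compounds shown here, in a functional assay on Ehrlich cells (Mus musculus) for cytotoxicity (a lower number here means a stronger inhibitor, a higher number a weaker inhibitor), compound 3 gives 143000 nM, the only number reported so far; compound 1 and compound 2 return no number in this assay. For the measured compounds named here, no step between two measured compounds is available, so there is no measured foundation for the next change.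

Compound 4 `COc1cc(N2C(N)=C(C#N)C(c3cccs3)C3=C2CC(C)(C)CC3=O)cc(OC)c1OC` differs from compound 3 in one place: thiophen-2-yl in place of 2-hydroxynaphthalen-1-yl on a saturated ring carbon. Nothing in the data shows how this change acts in this assay. A step in either direction beyond the scatter cannot be ruled out, but none is expected. Compound 4 is therefore estimated at 150000 nM, within 40000 nM to 600000 nM, an expected step of a 1.0-fold higher number from compound 3 to compound 4 (0.02 log units; within the scatter).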

Compound 4, half-maximal inhibitory concentration: "not active" (no number reported)
Compound 4: no number reported; there is nothing to compare the estimate with.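

Among the compounds shown here, compound 4 returns no number in this assay, so no step from compound 3 to compound 4 can be read. No measured evidence bears on this result. The compounds shown leave open how thiophen-2-yl compares with 2-hydroxynaphthalen-1-yl on the shared core.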